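The compounds below may be only part of what the source reports. "The series", "measured", "known", "first", "only" and "open" are said of these compounds alone.

In a functional assay on SMMC-7721 cells (Homo sapiens) for cytotoxicity, read by MTT assay, with a stated time of 4 days (a lower number here means a stronger inhibitor, a higher number a weaker inhibitor), three compounds have been measured so far.

Compound 1 `C=C1C[C@]23C[C@@]1(O)CC[C@@H]2c1cccc(C)c1[C@@H]3Cn1cc(-c2ccccn2)nn1` gives > 20000 nM, a limit of the assay.
Compound 2 `C=C1C(=O)[C@]23C[C@@]1(O)CC[C@H]2c1ccc(OS(=O)(=O)c2ccc(C)cc2)c(C)c1[C@@H]3Cn1cc(-c2ccc(C)cc2)nn1` gives 4410 nM.
Compound 3 `Cc1c(O)ccc2c1[C@H](Cn1cc(-c3ccc(C(F)(F)F)cc3)nn1)[C@@]13CC(=O)[C@@](C)(CC[C@@H]21)C3` gives > 20000 nM, again a limit of the assay.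

Among the measured compounds shown here, compound 2 therefore stands alone as the only true number in this assay; the remaining results are the limit of > 20000 nM in this assay, at which 2 of the 3 values shown sit. Compound 4 `C=C1C(=O)[C@]23C[C@@]1(O)CC[C@H]2c1ccc(OS(=O)(=O)c2ccc(C)cc2)c(C)c1[C@@H]3Cn1cc(-c2ccc(Br)cc2)nn1` has not yet been measured. It differs from compound 2 in a single place: bromo in place of methyl on an aromatic carbon. For the measured compounds named here, no measured pair of compounds shows this change, so there is nothing to anchor its size. Only a small step, within the usual scatter and without a clear direction, is expected: a 1.3-fold lower number from compound 2 to compound 4 (0.10 log units; within the scatter). Compound 4 is accordingly estimated to give about 3500 nM, within a range from 1200 nM to 12000 nM.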

Compound 4, half-maximal inhibitory concentration: 4320 nM
The estimate for compound 4 lay 1.2-fold (0.09 log units) below the measured number; low and high end bracket the measured number.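

Setting bromo in place of methyl on this aromatic carbon, para to a large group, gives a 1.0-fold lower number from compound 2 to compound 4 (0.01 log units; within the scatter), so this first measured change at the position leaves the number unmoved within the scatter. The 4-methylphenyl and 4-bromophenyl compounds cannot be told apart in this assay. Compound 4 supplies a second true number, while the other results remain limits of the assay: the limit of > 20000 nM in this assay, at which 2 of the 4 values shown sit.

From the compounds shown here alone, whether an amine, a carboxylic acid or a longer chain at this position would move the number stays open. Compounds 1 and 3 differ from compound 2 in more than one place, so the compounds shown do not tell which feature separates the true numbers from the limits.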